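Shrinking One Ring on the Amide Nitrogen

The compounds below may be only part of what the source reports. "The series", "measured", "known", "first", "only" and "open" are said of these compounds alone.

Within the data shown here, compound 1 `Cc1cc(C)cc(S(=O)(=O)c2c(C(=O)NC3CC4(CCN(S(C)(=O)=O)C4)C3)[nH]c3ccc(Cl)cc23)c1` is the only compound here with a definite number in a toxicity assay on MT4 cells (Homo sapiens) for cytotoxicity, read by MTT assay, with a stated time of 7 days; a higher number here means that more compound is tolerated, a lower number that less compound is tolerated: compound 1 gives 205000 nM. Compound 2 `Cc1cc(C)cc(S(=O)(=O)c2c(C(=O)NC3CC4(CCN(S(C)(=O)=O)CC4)C3)[nH]c3ccc(Cl)cc23)c1` reaches only a limit in this assay, where compound 2 gives > 221000 nM. That is the limit of > 221000 nM in this assay, at which 1 of the 2 values shown sits. Compound 3 `Cc1cc(C)cc(S(=O)(=O)c2c(C(=O)NC3CC4(C3)CN(S(C)(=O)=O)C4)[nH]c3ccc(Cl)cc23)c1` differs from compound 1 in one place: a group of 11 heavy atoms (7 carbon, 1 nitrogen, 2 oxygen, 1 sulfur; one four-membered non-aromatic ring of carbon only, one four-membered non-aromatic ring with 1 hetero atom) in place of a group of 12 heavy atoms (8 carbon, 1 nitrogen, 2 oxygen, 1 sulfur; one four-membered non-aromatic ring of carbon only, one five-membered non-aromatic ring with 1 hetero atom), on an amide-type nitrogen. Among the measured compounds shown here, no measured step exists to weigh such a change, so the step expected here, a 1.0-fold lower number from compound 1 to compound 3 (0.01 log units; within the scatter), is none beyond the usual scatter. Compound 3 is accordingly estimated at 200000 nM, with a range from 100000 nM to 400000 nM.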

Compound 3, half-maximal cytotoxic concentration: > 233000 nM
Compound 3: a limit, no number; the forecaster's own chance of this, stated with the estimate: 40%; at least 1.1-fold (0.06 log units) between middle value and limit.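

Compound 3 gives no number in this assay, only a limit: the limit of > 233000 nM in this assay, at which 1 of the 3 values shown sits. Replacing the five-membered non-aromatic ring with 1 hetero atom by the four-membered one, on this amide-type nitrogen, gives an at least 1.1-fold higher number from compound 1 to compound 3 (0.05 log units; that floor lies within the scatter). Among these compounds, this change therefore shows no sign that less compound is tolerated, although the true size of the step cannot be read.

The compounds shown leave open how an open-chain amine or a carboxylic acid on this amide-type nitrogen, in place of these ring groups, would fare in this assay.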